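The source may hold more compounds than are shown below. What is called first, only, known or untested is meant among the compounds shown, and "the series" means these compounds.

Measured so far, in a functional assay on SK-LU-1 cells (Homo sapiens) for antiproliferative activity, read by sulforhodamine B assay, with a stated time of 48 h, tested at 50 uM; a lower number here means less inhibition, a higher number more inhibition at the concentration tested (going by the name of the read-out):

- compound 1, `CC1=CC[C@H](C(C)C)c2cc(C)c(OC(=O)c3ccc(C)cc3)cc21`: compound 1 gives 85.4%
- compound 2, `CC1=CC[C@H](C(C)C)c2cc(C)c(OC(=O)Nc3ccccc3)cc21`: compound 2 gives 100%
- compound 3, `CC1=CC[C@H](C(C)C)c2cc(C)c(OC(=O)c3ccc([N+](=O)[O-])cc3)cc21`: compound 3 gives 47.5%

Compound 3 stands lowest of the three numbers; its nearest neighbour is compound 1, which lies higher by a number 37.9 percentage points lower from compound 1 to compound 3 (beyond the scatter), and its furthest is compound 2, higher by a number 52.5 percentage points lower from compound 2 to compound 3 (beyond the scatter). Compound 4, `CC1=CC[C@H](C(C)C)c2cc(C)c(OC(=O)c3ccccc3)cc21`, has not yet been measured. It differs from compound 3 in one place: hydrogen in place of nitro on an aromatic carbon.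

Going by the values given here, the step that bears most directly on this change is the one from compound 1 to compound 3, where nitro replaced methyl on the same aromatic carbon and the number fell by a number 37.9 percentage points lower from compound 1 to compound 3 (beyond the scatter). The step from compound 2 to compound 3, a number 52.5 percentage points lower from compound 2 to compound 3 (beyond the scatter), also shows that the 4-nitrophenyl compound sits well below the others. Taking the nitro away is therefore expected to move the number back up, though no measured pair tells how a plain phenyl compares with a 4-methylphenyl one. Compound 4 is estimated at 75%, in a range from 50% to 95%. This estimate means an expected step of a number 27.5 percentage points higher from compound 3 to compound 4 (beyond the scatter).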

Compound 4, a percentage reported as inhibition, at one concentration (the size of the read-out at that concentration, not a potency): 37%
Estimate against measurement, compound 4: 38 percentage points above; measured number below the stated range.
By their numbers in this assay, from the lowest: compound 4; then compound 3; then compound 1; then compound 2.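

In this assay, the step of a number 10.5 percentage points lower from compound 3 to compound 4 (beyond the scatter) shows that taking the nitro group off this aromatic carbon does not bring the number back up, so nitro alone does not account for the low value of compound 3. The step of a number 48.4 percentage points lower from compound 1 to compound 4 (beyond the scatter) adds that hydrogen, like nitro, stands far under methyl here, and of these three groups on this carbon, only methyl goes with high inhibition. The step of a number 63 percentage points lower from compound 2 to compound 4 (beyond the scatter) shows that the anilino compound also stands far above the plain phenyl compound, not just above the 4-nitrophenyl one.

On these data alone, whether other groups on this carbon, such as methoxy, chlorine or a longer chain like ethyl, would match methyl remains open. Nothing shown here explains why hydrogen and nitro both fall so far below methyl.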